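The source may hold more compounds than are shown below. What is called first, only, known or untested is meant among the compounds shown, and "the series" means these compounds.

In an ADME assay on microsomes from liver (Mus musculus) for metabolic stability, read by LC-MS, with a stated time of 30 min, tested at 1 ug/mL (on this read-out lower numbers stand for a less stable compound and higher numbers for a more stable compound), compound 2 `CC(C)C(=O)N1CCC(C[C@@H](c2nc3ccc(F)cc3n2C2CC2)N2C(=O)CN(c3ccc(Oc4ccc(F)cc4)cc3)C2=O)CC1` reaches 54% and stands highest of the two measured, above compound 1 `Cc1ccc2nc([C@H](CC3CCN(C(=O)C(C)C)CC3)N3C(=O)CN(c4ccc(Oc5ccc(F)cc5)cc4)C3=O)n(C3CC3)c2c1` at 43% in this comparison. Compound 3 `CC(C)C(=O)N1CCC(C[C@@H](c2nc3ccccc3n2C2CC2)N2C(=O)CN(c3ccc(Oc4ccc(F)cc4)cc3)C2=O)CC1` has hydrogen in place of fluoro on an aromatic carbon. Within the data shown here, the one measured step that bears on it is a number 11 percentage points higher from compound 1 to compound 2 (beyond the scatter) (fluoro in place of methyl on an aromatic carbon), modest and beyond the scatter. The step expected in this assay is small and downward, not clearly beyond the scatter (a number 8 percentage points lower from compound 2 to compound 3 (within the scatter)). Compound 3 is estimated at 46% (expected range 33% to 59%).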

Compound 3, percent of the compound remaining: 29.4%
Compound 3: middle estimate off by 16.6 percentage points, on the high side; the measured number lies below the stated range.
By their numbers in this assay, from the lowest: compound 3; then compound 1; then compound 2.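

The unsubstituted ring shows that this aromatic carbon counts for more in this assay than the swap of methyl for fluoro alone could show. Hydrogen in place of fluoro gives a clear loss (a number 24.6 percentage points lower from compound 2 to compound 3 (beyond the scatter)), and hydrogen in place of methyl also gives a loss (a number 13.6 percentage points lower from compound 1 to compound 3 (beyond the scatter)), so among these three compounds either group stands above hydrogen. Nothing available here explains these steps. On these data alone, whether chloro, methoxy or an amine on this carbon would match fluoro stays open, as does whether these steps hold on other versions of the shared core.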